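Chloro in Place of Hydrogen on the Fused Ring

This account rests on a few compounds, and the source may have more. Where it says the series, first, only, none or still open, it means among the compounds named here.

Compound 1 `O=S(=O)(c1ccc(-c2cnc(C3CC3)o2)cc1)N1CCc2ccccc21` gives 62 nM in a functional assay on PC-3 cells (Homo sapiens) for inhibition, read by MTT assay (on this read-out lower numbers stand for stronger inhibition and higher numbers for weaker inhibition), the lowest of the three numbers recorded so far. Compound 2 `COc1ccc2c(c1)CCN2S(=O)(=O)c1ccc(-c2cnc(C3CC3)o2)cc1` gives 82 nM; the step of a 1.3-fold higher number from compound 1 to compound 2 (0.12 log units; within the scatter) remains within the scatter. Compound 3 `O=[N+]([O-])c1ccc2c(c1)CCN2S(=O)(=O)c1ccc(-c2cnc(C3CC3)o2)cc1` gives 1920 nM, and the step of a 31-fold higher number from compound 1 to compound 3 (1.49 log units; beyond the scatter) is a large loss; likewise the step of a 23-fold higher number from compound 2 to compound 3 (1.37 log units; beyond the scatter) is large.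

Compound 4 `O=S(=O)(c1ccc(-c2cnc(C3CC3)o2)cc1)N1CCc2ccc(Cl)cc21` has not yet been measured. It differs from compound 1 by chloro in place of hydrogen on an aromatic carbon. For the measured compounds named here, two measured steps bear on this, both replacing a hydrogen on an aromatic carbon of compound 1: methoxy moved the number only within the scatter, whereas nitro brought a large loss. Chloro is a single halogen atom without donors or acceptors, and the one comparable small change, compound 2 with its 82 nM, stayed close to compound 1. For compound 4 a step of a 1.5-fold higher number from compound 1 to compound 4 (0.16 log units; within the scatter) is therefore expected, within the scatter. Compound 4 is estimated at 90 nM, with a range from 35 nM to 250 nM.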

Compound 4, half-maximal inhibitory concentration: 138 nM
Estimate against measurement, compound 4: 1.5-fold (0.19 log units) below, and the stated range covers the measured number.
By their numbers in this assay, from the lowest: compounds 1, 2 and 4 (each within the scatter of the next, the first and the last beyond it); then compound 3.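

With chloro on this carbon of the fused ring, the shared core loses some inhibition: a 2.2-fold higher number from compound 1 to compound 4 (0.35 log units; beyond the scatter) is a modest step, just beyond the scatter. This is the first substitution shown on this carbon, since compound 2 and compound 3 carry their groups on a different carbon of that ring, so the step cannot be set directly against theirs. Even so, it shows that a substituent here can leave inhibition in this assay in the same general range as compound 1, and no measurement shown explains the modest loss.

Going by these compounds, it remains open whether fluoro, an amine or a carboxylic acid on this same carbon would stay as close to compound 1. Also open, on these data alone, is how chloro would behave on the carbon that bears methoxy in compound 2.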